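Compound 1 to compound 4: a second hydroxy group

The source may hold more compounds than are shown below. What is called first, only, known or untested is meant among the compounds shown, and "the series" means these compounds.

In an ADME assay on HEK293 cells (Homo sapiens) for cytotoxicity, read by MTT assay, with a stated time of 48 h (on this read-out lower numbers stand for stronger inhibition and higher numbers for weaker inhibition), compound 1 (`O=C1/C(=C\c2ccc(O)cc2)S/C(=N/c2ccccc2)N1Cc1ccncc1`) gives 142000 nM. Compound 2 (`COc1ccc(/C=C2/S/C(=N/c3ccccc3)N(Cc3ccncc3)C2=O)cc1`) gives 47900 nM, and compound 3 (`CN(C)c1ccc(/C=C2/S/C(=N/c3ccccc3)N(Cc3ccncc3)C2=O)cc1`) gives 122000 nM. Compound 1 therefore stands at the top of a narrow range, level with compound 3 and above compound 2. The nearest comparison is a 1.2-fold lower number from compound 1 to compound 3 (0.07 log units; within the scatter), and the furthest is a 3.0-fold lower number from compound 1 to compound 2 (0.47 log units; beyond the scatter).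

Compound 4 (`O=C1/C(=C\c2ccc(O)c(O)c2)S/C(=N/c2ccccc2)N1Cc1ccncc1`) is not yet measured. It keeps the core of compound 1 and turns 4-hydroxyphenyl into 3,4-dihydroxyphenyl: hydroxy in place of hydrogen on an aromatic carbon. The new hydroxy sits ortho to a hydroxy group and meta to a large group.

The measured steps bear on this only indirectly, since each replaces one group on the ring and none adds a second. They remain modest at most, with a 2.5-fold higher number from compound 2 to compound 3 (0.41 log units; beyond the scatter) as a further example. For the measured compounds named here, no step clearly beyond the scatter is therefore expected in this assay, with a slight lean towards a lower number given the place of compound 1 at the top of the range. The expected step is a 1.6-fold lower number from compound 1 to compound 4 (0.20 log units; within the scatter). Compound 4 is estimated at 90000 nM, with an expected range of 35000 nM to 200000 nM.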

Compound 4, half-maximal inhibitory concentration: 230000 nM
The estimate for compound 4 lay 2.6-fold (0.41 log units) below the measured number; measured number above the stated range.
By their numbers in this assay, from the lowest: compound 2; then compounds 3, 1 and 4 (each within the scatter of the next).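

Adding a hydroxy group on an aromatic carbon of the six-membered ring, ortho to a hydroxy group and meta to a large group, is the first addition to this ring in the series rather than a replacement. In this assay it gives a 1.6-fold higher number from compound 1 to compound 4 (0.21 log units; within the scatter), so this position takes a second hydroxy group without a step that can be told from the scatter. Comparing whole ring groups, a 1.9-fold higher number from compound 3 to compound 4 (0.28 log units; within the scatter) also stays within the scatter, while a 4.8-fold higher number from compound 2 to compound 4 (0.68 log units; beyond the scatter) is beyond it, which leaves compound 2, with 4-methoxyphenyl, set apart from the other three compounds; no evidence on hand accounts for these numbers.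

On these data alone, whether an amine, a methoxy group or a carboxylic acid at this same place would also stay within the scatter of compound 1 remains open. As far as these compounds go, it is also open whether a hydroxy group added at this place on the 4-methoxyphenyl ring of compound 2 would leave its number unchanged, or whether the gap between compound 2 and the other compounds would close.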